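Methyl for Fluoro on the Aromatic Ring of Compound 2

The compounds below may be only part of what the source reports. "The series", "measured", "known", "first", "only" and "open" are said of these compounds alone.

Measured so far in an assay on Sf9 cells for inhibition of Amine oxidase [flavin-containing] B (Homo sapiens), with stated times of 15 min and 60 min; a lower number here means a stronger inhibitor, a higher number a weaker inhibitor:
compound 1 `C#CCN(Cc1ccc(OCc2cccc(F)c2)cc1Cl)[C@@H](C)C(N)=O` gives 68 nM
compound 2 `C#CCN(Cc1ccc(OCc2cccc(F)c2)cc1F)[C@@H](C)C(N)=O` gives 93 nM

Compound 2 carries the highest of the two numbers in this assay; its nearest neighbour is compound 1, and the gap between them is small. Among the measured compounds shown here, the one step measured, a 1.4-fold higher number from compound 1 to compound 2 (0.14 log units; within the scatter), exchanges chloro for fluoro at the same aromatic carbon and stays within the scatter.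

Compound 3 `C#CCN(Cc1ccc(OCc2cccc(F)c2)cc1C)[C@@H](C)C(N)=O` has not yet been measured. It differs from compound 2 by methyl in place of fluoro on an aromatic carbon. For the measured compounds named here, this change touches the same position as the one measured step, which gave no movement beyond the scatter, so the expected step from compound 2 to compound 3 in this assay is small as well, a 1.2-fold lower number from compound 2 to compound 3 (0.09 log units; within the scatter), leaning slightly toward a lower number. Compound 3 is therefore estimated at 75 nM, with a range from 35 nM to 160 nM.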

Compound 3, half-maximal inhibitory concentration: 320 nM
Estimate against measurement, compound 3: 4.3-fold (0.63 log units) below; the measured number lies above the stated range.
By their numbers in this assay, from the lowest: compounds 1 and 2 (each within the scatter of the next); then compound 3.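

In this assay, this aromatic carbon, which had taken chloro and fluoro with no movement beyond the scatter, proves sensitive to the group it carries: methyl gives a 3.4-fold higher number from compound 2 to compound 3 (0.54 log units; beyond the scatter) and a 4.7-fold higher number from compound 1 to compound 3 (0.67 log units; beyond the scatter). Both halogen compounds thus stand apart from the methyl compound, even though fluoro and methyl have the same computed counts of heavy atoms, hydrogen-bond donors and hydrogen-bond acceptors, so those counts do not separate them. Nothing available here accounts for the difference between these groups.

The compounds shown leave open where a hydrogen, a methoxy group or a trifluoromethyl group on this carbon would fall, and so whether methyl is a lone exception or part of a wider trend. They also leave open whether the step would keep its size with other changes elsewhere on the shared core.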